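The compounds below may be only part of what the source reports. "The series", "measured", "known", "first", "only" and "open" are said of these compounds alone.

Measured so far:
Compound 1 `COc1ccc(CN(C(=O)Nc2ccc(F)c(Cl)c2)n2cnnc2)cc1OC`: in a functional assay on DU-145 cells (Homo sapiens) for cytotoxicity, read by MTT assay, with a stated time of 48 h (a higher number here means a weaker inhibitor, a lower number a stronger inhibitor), compound 1 gives 23300 nM.
Compound 3 `COc1ccc(OC)c(CN(C(=O)NC2CCCCC2)n2cnnc2)c1`: in this assay compound 3 gives 29800 nM.
Compound 2 `CCCCCCCCCNC(=O)N(Cc1cc(OC)ccc1OC)n1cnnc1`: in this assay compound 2 reaches only a limit of the assay, > 50000 nM.

Compound 1 and compound 3 lie within the scatter of each other, so no order between them is read from these two numbers. The value of compound 2 is a limit and not a number; (the limit of > 50000 nM in this assay, at which 1 of the 3 values shown sits).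

Compound 4 `CCc1ccc(NC(=O)N(Cc2ccc(OC)c(OC)c2)n2cnnc2)cc1` is not yet measured. It differs from compound 1 in one place: 4-ethylphenyl in place of 3-chloro-4-fluorophenyl on an amide-type nitrogen. Among the measured compounds shown here, the only measured step also exchanges the group on the amide-type nitrogen, and it is small: an at least 1.6-fold lower number from compound 2 to compound 3 (0.22 log units; that floor lies within the scatter). Beyond that, compound 1 and compound 3, which carry different groups on that nitrogen, sit within the scatter of each other. Nothing shown points to a step beyond the scatter for the change from compound 1 to compound 4. The expectation for compound 4 is therefore a number close to that of compound 1, the expected step being a 1.1-fold higher number from compound 1 to compound 4 (0.03 log units; within the scatter). The estimate for compound 4 in this assay is 25000 nM, with a range from 10000 nM to 60000 nM.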

Compound 4, half-maximal inhibitory concentration: > 50000 nM
Compound 4: no number, only a limit; the forecaster's own chance of this, stated with the estimate: 15%; at least 2.0-fold (0.30 log units) between middle value and limit.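

In this assay, an at least 2.1-fold higher number from compound 1 to compound 4 (0.33 log units; beyond the scatter) is the only listed step in the series that lies beyond the scatter. It shows that this amide-type nitrogen does not tolerate every aromatic group equally: 3-chloro-4-fluorophenyl and 4-ethylphenyl match in heavy-atom count, each have one six-membered aromatic ring of carbon only and carry no hydrogen-bond donors or acceptors, yet they do not read alike here. Compound 4 gives a limit and not a number, so the step is only a floor, and a second group on this nitrogen now ends at that limit: the limit of > 50000 nM in this assay, at which 2 of the 4 values shown sit.

The compounds shown do not separate the effect of adding the ethyl group from that of losing the chlorine and the fluorine, nor the contribution of one halogen from the other; 4-fluorophenyl, 3-chlorophenyl or plain phenyl on the same nitrogen would bear on both questions. Also open, going by these compounds, is whether a number below the limit returns with a smaller alkyl group such as 4-methylphenyl, and how far compound 4 lies beyond its limit.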